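Aryl piperazine succinimides: chlorophenyl to fluorophenyl exchange

The compounds below may be only part of what the source reports. "The series", "measured", "known", "first", "only" and "open" are said of these compounds alone.

Compound 1 `CCC(C(=O)N1CCN(c2cccc(Cl)c2)CC1)N1C(=O)CCC1=O` is the reference point of this small set. In a functional assay on the whole organism (strain Swiss) with Mus musculus as the target, in the maximal electroshock model, with a stated time of 0.5 h, at a dose of 100 mg/kg by the intraperitoneal route (on this read-out higher numbers stand for a stronger effect at the one dose given and lower numbers for a weaker effect), compound 1 gives 50%, the highest of the two numbers recorded so far. Within the data shown here, compound 2 `CC(C(=O)N1CCN(c2ccccc2C(F)(F)F)CC1)N1C(=O)CCC1=O` differs from compound 1 at more than one place, so no single step can be drawn between the two; in this assay compound 2 gives 25%, a reading well below that of compound 1 and beyond the usual scatter. Compound 3 `CCC(C(=O)N1CCN(c2ccccc2F)CC1)N1C(=O)CCC1=O` is not yet measured. It departs from compound 1 by one change: 2-fluorophenyl in place of 3-chlorophenyl on an amine nitrogen in a ring. Among the measured compounds shown here, no measured pair shows this change, so any expectation rests only on the two numbers above and on the change itself. A modest loss is expected, of a size that may reach just beyond the scatter, as the step of a number 15 percentage points lower from compound 1 to compound 3 (beyond the scatter) expresses. For compound 3 the expected value in this assay is 35%, with a range from 10% to 65%.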

Compound 3, a percentage reported as activity, at one dose (the size of the read-out at that dose, not a potency): 0%
The estimate for compound 3 lay 35 percentage points above the measured number, outside the stated range (below it).
By their numbers in this assay, from the lowest: compound 3; then compound 2; then compound 1.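

In this assay, among these compounds, replacing 3-chlorophenyl with 2-fluorophenyl on the amine nitrogen in a ring gives a number 50 percentage points lower from compound 1 to compound 3 (beyond the scatter), the first step that can be read at a single place. The two groups match in heavy atoms, aromatic ring, hydrogen-bond counts and charge, yet they are not interchangeable here: the read-out at this one dose depends on which halogen-bearing phenyl sits at this position. No measurement at hand accounts for the loss.

The change alters both the halogen and its place on the phenyl ring, so the compounds shown do not separate these two contributions; 3-fluorophenyl and 2-chlorophenyl would do so. From the compounds shown here alone, whether an unsubstituted phenyl or a 3-methoxyphenyl at this position would keep the read-out of compound 1 also remains open.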